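Chloro in place of diethylamino on the shared core

The source may hold more compounds than are shown below. What is called first, only, known or untested is meant among the compounds shown, and "the series" means these compounds.

Compound 1 (`Cc1ccc(NC(=O)c2ncc(-c3ccccc3)o2)cc1`) gives > 30000 nM in a functional assay on HepG2 cells (Homo sapiens) for cytotoxicity, read by CCK-8 assay (on this read-out higher numbers stand for weaker inhibition and lower numbers for stronger inhibition), as a limit and not a number. Compound 2 (`CN(C)c1ccc(NC(=O)c2ncc(-c3ccccc3)o2)cc1`) gives > 30000 nM as a limit as well. Compound 3 (`CCN(CC)c1ccc(NC(=O)c2ncc(-c3ccccc3)o2)cc1`) gives > 30000 nM as a limit too. For the measured compounds named here, the series so far rests on the limit of > 30000 nM in this assay, at which 3 of the 3 values shown sit, and no compound can be ranked.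

The change to compound 4 (`O=C(Nc1ccc(Cl)cc1)c1ncc(-c2ccccc2)o1`) is chloro in place of diethylamino on an aromatic carbon, para to a large group: chloro in place of diethylamino on an aromatic carbon and the rest of the core stays the same.

The measured steps at this same place give no size: a step that the two limits leave unreadable from compound 1 to compound 2 is one, a step that the two limits leave unreadable from compound 1 to compound 3 is another and a step that the two limits leave unreadable from compound 2 to compound 3 is the third. None of them brings in chloro. The expectation of no large move rests on compound 3 at > 30000 nM as a limit. The expected step is an at least 1.2-fold lower number from compound 3 to compound 4 (0.07 log units; that floor lies within the scatter) in this assay and any readable move is expected only toward stronger inhibition. For compound 4 the estimate is 25000 nM with an expected range from 8000 nM to 60000 nM and another report as a limit is likely.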

Compound 4, half-maximal inhibitory concentration: > 30000 nM
Compound 4: a limit, no number; the forecaster's own chance of this, stated with the estimate: 65%; middle value at least 1.2-fold (0.07 log units) away from the limit.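

In this assay compound 4 gives > 30000 nM, a limit and not a number, so its steps from compound 1, compound 2 and compound 3 cannot be read, and the series still rests on one value: the limit of > 30000 nM in this assay, at which 4 of the 4 values shown sit.

The compounds shown leave open whether any group at this place on the shared core gives a readable value in this assay.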